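Amide cap variation in the trifluoromethyl ketone hydrate series

The source may hold more compounds than are shown below. What is called first, only, known or untested is meant among the compounds shown, and "the series" means these compounds.

Measured so far:
compound 1 `O=C(CCCCCCNC(=O)C(O)(O)C(F)(F)F)Nc1ccc(F)cc1` — 7570 nM
compound 2 `CC(=O)C(=O)NCCCCCC(=O)Nc1ccccc1` — > 100000 nM
compound 3 `O=C(CCCCCCNC(=O)C(O)(O)C(F)(F)F)Nc1ccc(S(F)(F)(F)(F)F)cc1` — 9110 nM

In a functional assay on HCT-116 cells (Homo sapiens) for inhibition, read by colorimetric assay, with a stated time of 3 days (a lower number here means a stronger inhibitor, a higher number a weaker inhibitor), compound 1 gives 7570 nM, the lowest of the two numbers recorded here; its nearest neighbour is compound 3 at 9110 nM, and the two sit within the scatter of each other. Compound 2 reports only a limit in this assay, > 100000 nM, so no number exists for it (the limit of > 100000 nM in this assay, at which 1 of the 3 values shown sits).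

Among the compounds with values here, the one measured step that bears on the cap, a 1.2-fold higher number from compound 1 to compound 3 (0.08 log units; within the scatter), shows that swapping the substituent on the aromatic carbon of the anilide leaves the read-out essentially unchanged.

Compound 4 `O=C(CCCCCCNC(=O)C(O)(O)C(F)(F)F)Nc1nc2ccccc2o1` carries a different cap altogether: 1,3-benzoxazol-2-yl in place of 4-fluorophenyl on an amide-type nitrogen. This replaces the whole 4-fluorophenyl rather than one substituent on it, so the step from compound 1 to compound 3 is only a partial guide; it suggests the cap region tolerates change, but gives no hint on a heteroaryl amide.

For compound 4 the expectation is therefore a number close to that of compound 1, with the step of a 1.1-fold higher number from compound 1 to compound 4 (0.05 log units; within the scatter) expected to stay near the scatter in either direction. Compound 4 is estimated at 8500 nM, with a range of 2500 nM to 30000 nM.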

Compound 4, half-maximal inhibitory concentration: 3450 nM
Compound 4: middle estimate off by 2.5-fold (0.39 log units), on the high side; the measured number falls inside the stated range.
By their numbers in this assay, from the lowest: compound 4; then compounds 1 and 3 (each within the scatter of the next). At a limit, above all of these: compound 2.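

In this assay the cap on the amide-type nitrogen does respond to a change of the whole group: 1,3-benzoxazol-2-yl in place of 4-fluorophenyl gives a 2.2-fold lower number from compound 1 to compound 4 (0.34 log units; beyond the scatter) and so moves the number beyond the scatter. The earlier step on this cap, a change of one substituent on the aromatic ring, gave a 1.2-fold higher number from compound 1 to compound 3 (0.08 log units; within the scatter) and did not do so. The entering group brings a five-membered aromatic ring with 2 hetero atoms and 2 hydrogen-bond acceptors, but nothing measured here ties the lower number to either feature.

A single step cannot show whether the lower number belongs to 1,3-benzoxazol-2-yl alone or extends to other heteroaryl caps, and a 1,3-benzothiazol-2-yl or a pyridin-2-yl cap on the same chain would help to separate those readings. From the compounds shown here alone, compound 2 reports > 100000 nM which is a limit and not a number, and it differs from the other compounds in more than one place, so the contribution of the trifluoromethyl ketone hydrate and of the chain length remains open.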